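Aryl-piperazine urea series: swapping the ortho substituent

The source may report more compounds than this note shows. Statements on the series, on what has been measured and on what is new or still open speak of the compounds shown alone.

Measured compounds:
- Compound 1, `COC(=O)C1=C(C)N=C(C)/C(=C(/O)OC)C1c1cccc(NC(=O)NCCNC2CCN(c3ccccc3[N+](=O)[O-])CC2)c1`, gives 2 nM in an assay on SK-N-MC cells for inhibition of Neuropeptide Y receptor type 1 (Homo sapiens); on this read-out higher numbers stand for weaker inhibition and lower numbers for stronger inhibition.
- Compound 2, `COC(=O)C1=C(C)N=C(C)/C(=C(/O)OC)C1c1cccc(NC(=O)NCCNC2CCN(c3ccccc3C#N)CC2)c1`, gives 3 nM in this assay.

For the measured compounds named here, compound 2 holds the highest of the two numbers, and its only neighbour is compound 1: the step of a 1.5-fold higher number from compound 1 to compound 2 (0.18 log units; within the scatter) is within the scatter, so the two compounds cannot be told apart on potency.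

Compound 3, `COC(=O)C1=C(C)N=C(C)/C(=C(/O)OC)C1c1cccc(NC(=O)NCCNC2CCN(c3ccccc3OC)CC2)c1`, differs from compound 2 by a single exchange: methoxy in place of cyano on an aromatic carbon, ortho to a large group.

Going by the values given here, only one measured step bears on this change, the exchange of nitro for cyano at the same aromatic carbon, which gave a 1.5-fold higher number from compound 1 to compound 2 (0.18 log units; within the scatter). That step shows the shared core tolerates a change of group at this position without a change beyond the scatter. Methoxy, however, has not been tested here, so the expectation rests on one step only.

The expected step of a 1.7-fold higher number from compound 2 to compound 3 (0.22 log units; within the scatter) is estimated to stay small. Compound 3 is estimated at 5 nM, with a range from 1.5 nM to 20 nM.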

Compound 3, half-maximal inhibitory concentration: 2 nM
Compound 3: middle estimate off by 2.5-fold (0.40 log units), on the high side, within the range that was stated.
By their numbers in this assay, from the lowest: compounds 1, 3 and 2 (each within the scatter of the next).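

With methoxy, the ortho position now holds a third group. Two earlier compounds could only show that nitro and cyano read alike, whereas methoxy has a different atom attached to the aromatic carbon, oxygen rather than carbon or nitrogen, and the picture stays the same. In this assay, the exchange of cyano for methoxy gives a 1.5-fold lower number from compound 2 to compound 3 (0.18 log units; within the scatter), and the exchange of nitro for methoxy gives no change at the digits printed from compound 1 to compound 3 (within the scatter), so compounds 1, 2 and 3 cannot be told apart on potency and no ranking of these three groups can be drawn from them. Nothing available here explains why the three groups read alike.

The compounds shown leave open how far this tolerance extends, for example whether a plain hydrogen, an amine, a carboxylic acid or a longer chain such as ethoxy on this aromatic carbon would also stay within the scatter of these three. Going by these compounds, it also remains open whether these three compounds would still match on any read-out other than this one, since a match in one binding test need not carry over to another.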